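Stereochemical inversion at the carbinol ring carbon of compound 1

The source may hold more compounds than are shown below. What is called first, only, known or untested is meant among the compounds shown, and "the series" means these compounds.

Compound 1 `C[C@@]1(c2ccc(OC(F)(F)F)cc2)C[C@@](O)(c2ccccn2)CO1` is the weaker of the two measured compounds: in an assay on HEK293 cells for antagonist activity at transient receptor potential cation channel subfamily V member 3 (Homo sapiens), read by FLIPR and calcium flux (a lower number here means a stronger inhibitor, a higher number a weaker inhibitor), compound 1 gives 1120 nM, while the ring-contracted analogue compound 2 `O[C@H](c1ccccn1)C1(c2ccc(OC(F)(F)F)cc2)CCC1` gives 140 nM, a gap beyond the usual scatter. Compound 3 `C[C@@]1(c2ccc(OC(F)(F)F)cc2)C[C@](O)(c2ccccn2)CO1` differs from compound 1 only in configuration: the two compounds have the same atoms and bonds and differ only in configuration as drawn: 1 of 2 stereo elements differ; a stereocentre at a saturated ring carbon is drawn R in compound 1 and S in compound 3. For the measured compounds named here, no measured pair isolates this change, so its effect is unknown. A step of moderate size is expected, in either direction, a 1.4-fold lower number from compound 1 to compound 3 (0.15 log units; within the scatter). Compound 3 is estimated at 800 nM, between 150 nM and 4000 nM.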

Compound 3, antagonist equilibrium constant: 1710 nM
Compound 3: the middle estimate sits 2.1-fold (0.33 log units) below what was measured; the range from low to high includes it.
By their numbers in this assay, from the lowest: compound 2; then compounds 1 and 3 (each within the scatter of the next).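

In this assay, changing a stereocentre at a saturated ring carbon from R to S gives a 1.5-fold higher number from compound 1 to compound 3 (0.18 log units; within the scatter). With the other stereo element held as drawn, configuration at this position does not separate the two compounds, and this is the first reading in the series that isolates it: the fact that compounds 1 and 3 differ only in the configuration as drawn

The compounds shown leave open whether this holds when the other stereo element is also inverted. They also leave open whether configuration here matters with an amine in place of the hydroxyl.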